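A few compounds are considered here, and "the series" means these few. Any claim that something is new, unique, unknown or untested is made for them only; others in the source may bear on it.

Within the data shown here, in an ADME assay on SH-SY5Y cells (Homo sapiens) for cytotoxicity, read by MTT assay, with a stated time of 72 h (a lower number here means a stronger inhibitor, a higher number a weaker inhibitor), three compounds built on a shared core have numbers so far. Compound 1 (`O=C(CN1CCN(C(=O)c2ccc(Cl)cc2)CC1)N1CCN(CCCc2c[nH]c3ccccc23)CC1`) gives 139000 nM, compound 2 (`O=C(CN1CCN(C(=O)c2cccc(F)c2)CC1)N1CCN(CCCc2c[nH]c3ccccc23)CC1`) gives 165000 nM, and compound 3 (`O=C(CN1CCN(C(=O)c2ccc(Cl)cc2)CC1)N1CCN(CCCc2c[nH]c3ccc(F)cc23)CC1`) gives 125000 nM. Compound 3 therefore stands within the scatter of both other compounds, and the three values do not separate.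

Compound 4 (`O=C(CN1CCN(C(=O)c2ccc(Br)cc2)CC1)N1CCN(CCCc2c[nH]c3ccc(F)cc23)CC1`) differs from compound 3 by bromo in place of chloro on an aromatic carbon. Among the measured compounds shown here, no measured step makes this exact exchange, but two bear on it. Replacing 4-chlorophenyl on the carbonyl carbon gives a 1.2-fold higher number from compound 1 to compound 2 (0.07 log units; within the scatter), and this is the closer precedent. Fluoro in place of hydrogen on an aromatic carbon gives a 1.1-fold lower number from compound 1 to compound 3 (0.05 log units; within the scatter). Both steps lie within the scatter, so no change beyond the scatter is expected in this assay, and no direction can be named. The expected step is no change at the digits printed from compound 3 to compound 4 (within the scatter). The estimate for compound 4 is 125000 nM, with an expected range from 80000 nM to 190000 nM.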

Compound 4, half-maximal inhibitory concentration: 47400 nM
Beside the measured number, compound 4's estimate is 2.6-fold (0.42 log units) above it, outside the stated range (below it).
By their numbers in this assay, from the lowest: compound 4; then compounds 3, 1 and 2 (each within the scatter of the next).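

In this assay, among these compounds, the exchange of chloro for bromo on the aromatic carbon para to a large group is the first single change in this set to move beyond the scatter, with a 2.6-fold lower number from compound 3 to compound 4 (0.42 log units; beyond the scatter). The earlier change at this aryl group, from 4-chlorophenyl to 3-fluorophenyl, and the fluoro added to the other end of the molecule both stayed within it, so this position responds to a swap of one halogen for another, although neither halogen adds a ring, a hydrogen-bond donor or acceptor, or a net charge. Nothing measured on these compounds accounts for the step.

The compounds shown leave open whether bromo in place of chloro gives a similar step on the core of compound 1, which lacks the fluoro. They also leave open whether iodo or methyl on the same aromatic carbon would extend the step, reverse it or leave the number unchanged.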